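The compounds below may be only part of what the source reports. "The series", "measured", "known", "first", "only" and "open" are said of these compounds alone.

Working notes on the series.

Three measured compounds carry the shared sulfonyl-substituted core with an aminoethyl chain on the ring nitrogen. Compound 1 `NCCn1cc(S(=O)(=O)c2ccccc2)c2cc(F)ccc21` gives 27 nM in an assay on HeLa cells for binding affinity to 5-hydroxytryptamine receptor 6 (Homo sapiens); on this read-out higher numbers stand for weaker inhibition and lower numbers for stronger inhibition. Compound 2 `CNCCn1cc(S(=O)(=O)c2ccccc2)c2ccccc21` gives 15.5 nM in this assay. Compound 3 `COc1ccc2c(S(=O)(=O)c3ccccc3)cn(CCN(C)C)c2c1` gives 23 nM in this assay. Compound 3 stands second highest of the three numbers; its nearest neighbour is compound 1, with a slightly higher number, and its furthest is compound 2, with a somewhat lower number, and both gaps lie within the usual scatter of this assay. Among the measured compounds shown here, no single-point step between measured compounds is available, so the three values only show that the series so far sits in a narrow band.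

The unmeasured compound 4 `CN(C)CCn1cc(S(=O)(=O)c2ccccc2)c2ccc(Cl)cc21` differs from compound 3 by chloro in place of methoxy on an aromatic carbon. For the measured compounds named here, the chloro substituent sits at a different position on the fused six-membered ring than the fluoro of compound 1, so no measured pair isolates this change.

Given the narrow band of the three measured values, compound 4 is expected to give a number close to that of compound 3, with the step from compound 3 to compound 4 estimated as a 1.2-fold lower number from compound 3 to compound 4 (0.06 log units; within the scatter), not beyond the scatter in either direction. Compound 4 is estimated at 20 nM, with a range from 8 nM to 50 nM.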

Compound 4, inhibition constant: 42 nM
For compound 4 the middle estimate is 2.1-fold (0.32 log units) below the measured one, and the stated range covers the measured number.
By their numbers in this assay, from the lowest: compounds 2, 3, 1 and 4 (each within the scatter of the next, the first and the last beyond it).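

Among the compounds shown here, this is the first step that changes a single place: in this assay chloro in place of methoxy on an aromatic carbon of the six-membered aromatic ring gives a 1.8-fold higher number from compound 3 to compound 4 (0.26 log units; within the scatter), so at this position the two groups cannot be told apart on this read-out. The exchange replaces a group of two heavy atoms holding one hydrogen-bond acceptor with a single chlorine holding none, and the step still stays within the scatter, which the three earlier compounds, differing from one another in more than one place, could not show. No measurement on hand speaks to what lies behind this result.

A single pair cannot show whether this carbon accepts any group, and a nitrile, a carboxylic acid or a primary amine on the same carbon would test that more sharply than another halogen. For the compounds shown here, the chain on the ring nitrogen also remains unresolved, since no pair isolates aminoethyl against its methylated forms, and a longer chain such as aminopropyl would extend that question.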